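The source may report more compounds than this note shows. Statements on the series, on what has been measured and on what is new or still open speak of the compounds shown alone.

Measured compounds:
Compound 1, `CC1(C)OCC(Cn2cc(Cn3c4c(c5ccccc53)C(=O)c3c[n+]([O-])c5ccccc5c3C4=O)nn2)O1`, 330 nM
Compound 2, `O=C1c2c[n+]([O-])c3ccccc3c2C(=O)c2c1c1ccccc1n2Cc1cn(CC(O)CO)nn1`, 440 nM
Compound 3, `O=C1c2c[n+]([O-])c3ccccc3c2C(=O)c2c1c1ccccc1n2Cc1cn([C@@H]2O[C@H](CO)[C@@H](O)[C@H](O)[C@H]2O)nn1`, 230 nM

Of the compounds shown here, three sharing one core have been measured in a functional assay on A-375 cells (Homo sapiens) for cytotoxicity, read by MTT assay, with a stated time of 72 h; a higher number here means a weaker inhibitor, a lower number a stronger inhibitor. Compound 2 gives 440 nM, the highest of the three numbers, but its neighbours sit close: the step of a 1.3-fold higher number from compound 1 to compound 2 (0.12 log units; within the scatter) and the step of a 1.9-fold lower number from compound 2 to compound 3 (0.28 log units; within the scatter) both fall within the scatter, as does a 1.4-fold lower number from compound 1 to compound 3 (0.16 log units; within the scatter). Nothing among the three separates one from another.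

Compound 4 is `CN1CCN(CCCCCn2c3c(c4ccccc42)C(=O)c2c[n+]([O-])c4ccccc4c2C3=O)CC1`. It departs from compound 2 by 4-(4-methylpiperazin-1-yl)butyl in place of 1-(2,3-dihydroxypropyl)-1H-1,2,3-triazol-4-yl on a saturated chain carbon bound to an aromatic nitrogen. Among the measured compounds shown here, none of the measured steps covers a change of this kind; each of them swaps one oxygen-bearing group for another while the same five-membered aromatic ring stays in place. For the measured compounds named here, those steps were all small, so the only guidance they give is that alterations at this end of the molecule have not moved the number so far. Compound 2 serves as the anchor because a 1.9-fold lower number from compound 2 to compound 3 (0.28 log units; within the scatter) and a 1.3-fold higher number from compound 1 to compound 2 (0.12 log units; within the scatter) were both within the scatter. Compound 4 is therefore expected to land near it, with a 1.3-fold lower number from compound 2 to compound 4 (0.10 log units; within the scatter) as the estimated step and a wide range to reflect the untested nature of the change. The estimate for compound 4 is 350 nM, expected between 100 nM and 1200 nM.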

Compound 4, half-maximal inhibitory concentration: 1710 nM
The estimate for compound 4 lay 4.9-fold (0.69 log units) below the measured number, and the stated range ends below it.
By their numbers in this assay, from the lowest: compounds 3, 1 and 2 (each within the scatter of the next); then compound 4.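

Replacing 1-(2,3-dihydroxypropyl)-1H-1,2,3-triazol-4-yl with 4-(4-methylpiperazin-1-yl)butyl on a saturated chain carbon bound to an aromatic nitrogen gives, in this assay, a 3.9-fold higher number from compound 2 to compound 4 (0.59 log units; beyond the scatter), the first listed step in this series to lie beyond the scatter. The earlier steps shown here all kept the five-membered aromatic ring and exchanged only the oxygen-bearing groups on it, and none of them moved the number beyond the scatter; this modest step shows that the number can respond at this position when that ring is replaced, although the ring, the chain and the counts of donors and acceptors all change at once. No experimental evidence is available here to explain the rise.

The compounds shown leave open which part of the exchange goes with the step: the loss of the 1,2,3-triazole, the butyl chain or the 4-methylpiperazin-1-yl group. A plain pentyl group, a morpholine on the same chain, or a dimethylamino group carried on the 1,2,3-triazole would help to separate these parts.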